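Replacing the Cyclohexyl Group of Compound 1 with Isopropylamino

The compounds below may be only part of what the source reports. "The series", "measured", "known", "first", "only" and "open" are said of these compounds alone.

Measured so far:
Compound 1 `COC(=O)/C=C/c1cccc(N(Cc2ccc(/C=C/c3cccc(F)c3)cc2)C(=O)C2CCCCC2)c1`: 86 nM
Compound 2 `COC(=O)/C=C/c1cccc(N(Cc2ccc(/C=C/c3ccc(OC)cc3)cc2)C(=O)C2CCCCC2)c1`: 208 nM

Both compounds were tested in an assay on isolated protein with Bile acid receptor (Homo sapiens) as the target; a higher number here means that more compound is needed for the effect, a lower number that less compound is needed. Among the measured compounds shown here, compound 1 stands at the lower of the two numbers, and the only measured step, a 2.4-fold higher number from compound 1 to compound 2 (0.38 log units; beyond the scatter), concerns a change at the far end of the molecule, on the double-bonded chain.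

Compound 3 `COC(=O)/C=C/c1cccc(N(Cc2ccc(/C=C/c3cccc(F)c3)cc2)C(=O)NC(C)C)c1` differs from compound 1 in a different place: isopropylamino in place of cyclohexyl on a carbonyl carbon. A ring of six carbons, with no hydrogen-bond donor, gives way to a smaller open chain carrying one hydrogen-bond donor, and the carbonyl now sits between two nitrogens. For the measured compounds named here, no measured step bears on this change. Going by the values given here, the one step that is known, between compound 1 and compound 2, tells nothing about the carbonyl side, so there is no measured basis for the direction or size of the step to compound 3.

Compound 3 is therefore expected, with little confidence, to give about 200 nM, somewhere between 50 nM and 1000 nM. That estimate amounts to an expected 2.3-fold higher number from compound 1 to compound 3 (0.37 log units; beyond the scatter).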

Compound 3, half-maximal effective concentration: 467 nM
Beside the measured number, compound 3's estimate is 2.3-fold (0.37 log units) below it; the measured number falls inside the stated range.
By their numbers in this assay, from the lowest: compound 1; then compound 2; then compound 3.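

In this assay, the change on the carbonyl carbon gives a 5.4-fold higher number from compound 1 to compound 3 (0.73 log units; beyond the scatter), the first measured sign that this side of the molecule also affects the number, and not only the far end of the double-bonded chain. The direction is also now known for this pair: with the rest of compound 1 held constant, isopropylamino needs more compound than cyclohexyl does, but the swap removes the six-membered ring, reduces the group from 6 heavy atoms to 4 and adds a nitrogen with 1 hydrogen-bond donor, all in one step, so the result cannot be assigned to any one of these differences. Nothing in the information available explains the step.

Two groups on the same carbonyl carbon would help to separate these differences: cyclohexylamino, which keeps the ring and adds the nitrogen, and isopropyl, which keeps an open chain without the nitrogen. Going by these compounds, it also remains open whether isopropylamino would have a similar effect alongside the 4-methoxyphenyl group of compound 2.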